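Effect of a tert-butyl group on antiproliferative potency

The compounds below may be only part of what the source reports. "The series", "measured", "known", "first", "only" and "open" are said of these compounds alone.

Of the compounds shown here, three that share a common core have been tested in a functional assay on Daudi cells (Homo sapiens) for antiproliferative activity; on this read-out lower numbers stand for stronger inhibition and higher numbers for weaker inhibition. In this assay compound 1 `Nc1ncnc2c1c(-c1ccc(NC(=O)c3ccccc3)cc1)cn2[C@H]1CCN(C[C@@H]2CO2)C1` gives 3180 nM. Compound 2 `Nc1ncnc2c1c(-c1ccc(Oc3ccccc3)cc1)cn2[C@H]1CCN(C[C@@H]2CO2)C1` differs from compound 1 only in one group; read from compound 2 to compound 1 the difference is benzamido in place of phenoxy on an aromatic carbon. In this assay compound 2 gives 5480 nM, so that a 1.7-fold higher number from compound 1 to compound 2 (0.24 log units; within the scatter). Compound 3 `CC(C)(C)c1ccc(Oc2ccc(-c3cn([C@H]4CCN(C[C@@H]5CO5)C4)c4ncnc(N)c34)cc2)cc1` carries one more group than compound 2, (tert-butyl in place of hydrogen on an aromatic carbon), and in this assay compound 3 gives 6490 nM. The step of a 1.2-fold higher number from compound 2 to compound 3 (0.07 log units; within the scatter), and the step of a 2.0-fold higher number from compound 1 to compound 3 (0.31 log units; beyond the scatter). Compound 1 thus has the lowest number of the three, but its gap to compound 2 lies within the scatter, so no order between those two can be claimed.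

Compound 4 `CC(C)(C)c1ccc(C(=O)Nc2ccc(-c3cn([C@H]4CCN(C[C@@H]5CO5)C4)c4ncnc(N)c34)cc2)cc1` has not yet been measured. It stands to compound 1 as compound 3 stands to compound 2: tert-butyl in place of hydrogen on an aromatic carbon. The change is of the same kind as that from compound 2 to compound 3, with the same place description, while the surroundings differ in the way the core difference from compound 2 to compound 1 describes. Because a 1.2-fold higher number from compound 2 to compound 3 (0.07 log units; within the scatter) stayed within the scatter, the step expected for compound 4 is a 1.1-fold higher number from compound 1 to compound 4 (0.05 log units; within the scatter). The estimate for compound 4 is 3600 nM, with the expected range running from 1800 nM to 7500 nM.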

Compound 4, half-maximal inhibitory concentration: 5980 nM
The estimate for compound 4 lay 1.7-fold (0.22 log units) below the measured number, within the range that was stated.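

In this assay, setting tert-butyl in place of hydrogen on an aromatic carbon of compound 1 gives a step that cannot be told apart from repeat-measurement noise: a 1.9-fold higher number from compound 1 to compound 4 (0.27 log units; within the scatter). Set beside the earlier case, the two steps do not differ by more than such noise allows: the same change on two cores in this assay, a 1.2-fold higher number (0.07 log units; within the scatter) from compound 2 to compound 3 and a 1.9-fold higher number (0.27 log units; within the scatter) from compound 1 to compound 4, 1.6-fold (0.20 log units) apart, within the scatter of two such steps. This shows that, across these two cores, the change behaved alike within the precision of the assay, with neither step large enough to count as a real loss or gain; it does not show that tert-butyl has no effect at all, as a small real effect could lie hidden within the scatter, and two pairs of compounds say nothing about how the change would behave on any other core.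

The compounds shown leave open whether a different group on the same aromatic carbon, such as methyl, methoxy, an amine or a carboxylic acid, would move the number beyond the scatter. They also leave open whether tert-butyl would behave the same way with a link other than those in phenoxy and benzamido, such as a methylene.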